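From 3,4-difluorophenyl to 3,4-dimethoxyphenyl on the sulfonyl sulfur

The source may report more compounds than this note shows. Statements on the series, on what has been measured and on what is new or still open speak of the compounds shown alone.

Measured in an ADME assay on U2OS cells (Homo sapiens) for cytotoxicity, with a stated time of 96 h (on this read-out higher numbers stand for lower toxicity in this test and lower numbers for higher toxicity in this test), so far:
- compound 1 (`Cc1nccn1-c1ccc(Cn2ccnc2-c2cc3ccccc3[nH]c2=O)cc1`) gives 52900 nM
- compound 2 (`CC(C)COc1ccc(CN(Cc2ccncc2)S(=O)(=O)c2cccc(F)c2)cc1`) gives > 200000 nM (a limit of the assay, not a number)
- compound 3 (`CC(C)COc1ccc(CN(Cc2ccncc2)S(=O)(=O)c2ccc(F)c(F)c2)cc1`) gives 11500 nM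

Compound 3 stands lowest, beyond the scatter from compound 1, which is higher at 52900 nM. Going by the values given here, the change to compound 4 (`COc1ccc(S(=O)(=O)N(Cc2ccncc2)Cc2ccc(OCC(C)C)cc2)cc1OC`) is 3,4-dimethoxyphenyl in place of 3,4-difluorophenyl on a sulfonyl sulfur and no measured compound carries the entering group. Among the compounds with values here, the one measured step bearing on it is an at least 17-fold lower number from compound 2 to compound 3 (1.24 log units; beyond the scatter) and it starts from a limit, so its true size is open. With both fluoro groups leaving, a higher number is expected in this assay but only a moderate move. The expected step is a 3.0-fold higher number from compound 3 to compound 4 (0.48 log units; beyond the scatter) and it remains uncertain. Compound 4 is estimated at 35000 nM within a range of 8000 nM to 160000 nM in the same read-out.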

Compound 4, half-maximal cytotoxic concentration: 21700 nM
Compound 4: the middle estimate sits 1.6-fold (0.21 log units) above what was measured, and the stated range covers the measured number.
By their numbers in this assay, from the lowest: compounds 3 and 4 (each within the scatter of the next); then compound 1. At a limit, above all of these: compound 2.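

In this assay, 3,4-dimethoxyphenyl in place of 3,4-difluorophenyl on the sulfonyl sulfur gives a 1.9-fold higher number from compound 3 to compound 4 (0.28 log units; within the scatter), so the two compounds cannot be ordered. The low level seen with 3,4-difluorophenyl therefore does not depend on fluoro groups at this position. The same holds in an at least 9.2-fold lower number from compound 2 to compound 4 (0.96 log units; beyond the scatter), a step of open size whose start is a limit of the assay: the limit of > 200000 nM in this assay, at which 1 of the 4 values shown sits.

Open, from the compounds shown here alone, is how an unsubstituted phenyl or a chlorophenyl group on the sulfonyl sulfur would read. Also open, going by these compounds, is what separates 3-fluorophenyl from the two groups at the low level.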